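A few compounds are considered here, and "the series" means these few. Any claim that something is new, unique, unknown or untested is made for them only; others in the source may bear on it.

In a functional assay on cells for antagonist activity at Free fatty acid receptor 1 (Homo sapiens), read by TR-FRET and inositol phosphate accumulation, with a stated time of 2 h (on this read-out higher numbers stand for weaker inhibition and lower numbers for stronger inhibition), compound 3 `Fc1ccc(OCc2cc(OCC(F)(F)F)nc(-c3ccccn3)n2)c(F)c1F` gives 7.94 nM, the lowest of the two numbers shown. Compound 2 `Fc1ccc(OCc2cc(N3CC4(CCO4)C3)nc(-c3ccccn3)n2)c(F)c1F` gives 501 nM, and the step of a 63-fold lower number from compound 2 to compound 3 (1.80 log units; beyond the scatter) lies well beyond the scatter. Compound 1 `CC(=O)Nc1ccccc1OCc1cc(C)nc(-c2ccccn2)n1` reaches only a limit of this assay, > 39800 nM (the limit of > 39800 nM in this assay, at which 1 of the 3 values shown sits), so it yields no number.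

Compound 4 `COC1(COc2cc(COc3ccc(F)c(F)c3F)nc(-c3ccccn3)n2)COC1` differs from compound 3 by 3-methoxyoxetan-3-yl in place of trifluoromethyl on a saturated chain carbon bound to an oxygen on an aromatic ring. Going by the values given here, the only measured step that bears on this change is a 63-fold lower number from compound 2 to compound 3 (1.80 log units; beyond the scatter), in which a group built from two four-membered rings, each with one hetero atom, gave way to the trifluoroethoxy side chain and the number fell sharply. Compound 4 goes the other way in part: it keeps the methoxy-methylene link to the shared core but brings a four-membered ring with one hetero atom back in place of the trifluoromethyl. The account therefore expects the number for compound 4 to rise against compound 3, though by less than that earlier step, since the oxygen link of compound 3 is retained. Compound 4 is expected to give 50 nM, between 8 nM and 320 nM, an estimated step of a 6.3-fold higher number from compound 3 to compound 4 (0.80 log units; beyond the scatter).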

Compound 4, half-maximal inhibitory concentration: 501 nM
Compound 4: middle estimate off by 10-fold (1.00 log units), on the low side; the whole stated range lies below it.
By their numbers in this assay, from the lowest: compound 3; then compounds 2 and 4 (each within the scatter of the next). At a limit, above all of these: compound 1.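

In this assay, the oxygen link to the shared core does not by itself hold the low number of compound 3: with that link kept, 3-methoxyoxetan-3-yl in place of trifluoromethyl gives a 63-fold higher number from compound 3 to compound 4 (1.80 log units; beyond the scatter) and so removes the whole gain seen earlier. The group at the end of this chain therefore matters as much here as the earlier change on the aromatic carbon did, and no change at the digits printed from compound 2 to compound 4 (within the scatter) puts two quite different groups on the same level. Nothing measured here gives a reason for this step.

Going by these compounds, it remains open whether the oxetane ring or the methoxy group on it accounts for the rise. On these data alone, it is also open whether a plain ethyl, a 2-fluoroethyl or a 3,3,3-trifluoropropyl chain would stay close to compound 3.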